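Replacing 3-chlorophenyl with 3-bromo-4-fluorophenyl on the amide

The compounds below may be only part of what the source reports. "The series", "measured", "known", "first", "only" and "open" are said of these compounds alone.

- compound 1 `CC(C)c1ccc(NC(=O)C2CCN(C/C=C/c3ccccc3)CC2)cc1` gives 9100 nM in a functional assay on MCF7 cells (Homo sapiens) for inhibition, read by MTT assay, with a stated time of 72 h; on this read-out lower numbers stand for stronger inhibition and higher numbers for weaker inhibition
- compound 2 `O=C(Nc1cccc(Cl)c1)C1CCN(C/C=C/c2ccccc2)CC1` gives 16100 nM in this assay

Only these two compounds have been measured so far. Compound 2 at 16100 nM lies within the scatter of compound 1 at 9100 nM on this read-out, so the two cannot be ranked.

The next compound, compound 3 `O=C(Nc1ccc(F)c(Br)c1)C1CCN(C/C=C/c2ccccc2)CC1`, keeps the core of compound 2 and changes one group: 3-bromo-4-fluorophenyl in place of 3-chlorophenyl on an amide-type nitrogen. Neither measured compound carries 3-bromo-4-fluorophenyl.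

Among the compounds with values here, one measured step bears on this change, since it falls at the same amide-type nitrogen. That step is a 1.8-fold higher number from compound 1 to compound 2 (0.25 log units; within the scatter) and it stays within the scatter. Within the data shown here, with only this small step as a guide, no shift beyond the scatter is expected in either direction in this assay for the new group.

The estimated step is a 1.2-fold lower number from compound 2 to compound 3 (0.09 log units; within the scatter) and it too is expected to stay within the scatter.

In this assay compound 3 is estimated at 13000 nM with an expected range of 6500 nM to 26000 nM on this read-out.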

Compound 3, half-maximal inhibitory concentration: 13500 nM
Beside the measured number, compound 3's estimate is 1.0-fold (0.02 log units) below it, and the stated range covers the measured number.
By their numbers in this assay, from the lowest: compounds 1, 3 and 2 (each within the scatter of the next).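

In this assay, putting 3-bromo-4-fluorophenyl in place of 3-chlorophenyl on an amide-type nitrogen gives a 1.2-fold lower number from compound 2 to compound 3 (0.08 log units; within the scatter), so a phenyl group carrying both bromine and fluorine cannot be told apart from one carrying chlorine alone. Measured against the 4-isopropylphenyl group at the same nitrogen, the new group gives a 1.5-fold higher number from compound 1 to compound 3 (0.17 log units; within the scatter), which means that all three substituted phenyl groups now lie within the scatter of one another and none can be ranked. Within the data shown here, the earlier pair offered only a single small step, whereas the three compounds together show that replacing these groups at this nitrogen has so far produced no step beyond the scatter, although nothing available offers a reason for that flat result.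

The compounds shown leave open whether a phenyl group bearing an amine or a carboxylic acid at this nitrogen would move the number beyond the scatter. They also leave open whether any change elsewhere in the shared core would do so, since that part stays the same in all three compounds.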